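Cinnamamide quinazolines: 4-bromophenyl for 2,3-dichlorophenyl

The source may report more compounds than this note shows. Statements on the series, on what has been measured and on what is new or still open speak of the compounds shown alone.

Measured so far in a functional assay on A549 cells (Homo sapiens) for cytotoxicity, read by MTT assay, with a stated time of 72 h; a lower number here means a stronger inhibitor, a higher number a weaker inhibitor:
- compound 1, `COc1ccc(/C=C/C(=O)Nc2cc3c(Nc4ccc(F)c(Cl)c4)ncnc3cc2OC)c(OC)c1`, gives 33300 nM
- compound 2, `O=C(/C=C/c1cccc(Cl)c1Cl)Nc1cc2c(Nc3ccc(F)c(Cl)c3)ncnc2cc1O[C@H]1CCOC1`, gives 23200 nM

Both numbers lie in the weak range of this assay. Compound 2 stands within the scatter of compound 1: the gap between them is below what repeated measurements of this kind resolve, so the two compounds are not separated on the data at hand. For the measured compounds named here, no step between them is counted, since they differ in more than one place.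

Compound 3, `O=C(/C=C/c1ccc(Br)cc1)Nc1cc2c(Nc3ccc(F)c(Cl)c3)ncnc2cc1O[C@H]1CCOC1`, keeps the core of compound 2 and changes only the aryl group on the unsaturated chain:

4-bromophenyl in place of 2,3-dichlorophenyl on a double-bonded chain carbon bound to a double-bonded chain carbon

Nothing measured here isolates the effect of this exchange. With compound 1 and compound 2 both weak and indistinguishable despite different aryl groups, the series gives no sign that this part of the molecule moves the number much. The expected step is a 1.1-fold higher number from compound 2 to compound 3 (0.03 log units; within the scatter), none beyond the scatter. Compound 3 is therefore estimated at 25000 nM in this assay, in the range 10000 nM to 60000 nM.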

Compound 3, half-maximal inhibitory concentration: 35300 nM
The estimate for compound 3 lay 1.4-fold (0.15 log units) below the measured number; low and high end bracket the measured number.
By their numbers in this assay, from the lowest: compounds 2, 1 and 3 (each within the scatter of the next).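

In this assay, for the compounds shown here, the exchange of 2,3-dichlorophenyl for 4-bromophenyl on a double-bonded chain carbon bound to a double-bonded chain carbon gives a 1.5-fold higher number from compound 2 to compound 3 (0.18 log units; within the scatter) and thus provides the first one-place comparison at this position, one that does not separate the two aryl groups. On this single pair, a phenyl ring carrying two chlorine atoms and one carrying a bromine atom cannot be told apart at this position, and both compounds remain in the weak range of the assay, so the exchange opens no route to a stronger inhibitor. No measurement at hand bears on the reason for this outcome.

On these data alone, both aryl groups carry only halogen, so it remains open whether a phenyl ring bearing a dimethylamino group or a carboxylic acid, or a longer chain in place of the 2-arylethenyl unit, would shift the number beyond the scatter. Steps involving compound 1 cannot be read, since it differs from the other two compounds in more than one place, which leaves the contribution of the remaining parts of the molecule unresolved.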